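The source may hold more compounds than are shown below. What is called first, only, known or untested is meant among the compounds shown, and "the series" means these compounds.

In a functional assay on A549 cells (Homo sapiens) for inhibition, read by CCK-8 assay, with a stated time of 72 h, tested at 10 uM (on this read-out lower numbers stand for less inhibition of growth and higher numbers for more inhibition of growth at the one concentration tested), compound 1 `CN(C)C(=O)c1cc2cnc(Nc3ccc(NC(=O)C4(C(=O)Nc5ccccc5F)CC4)cc3)nc2n1C1CCCC1` gives 88.6% and compound 2 `CN(C)C(=O)c1cc2cnc(Nc3ccc(NC(=O)C4(C(=O)Nc5ccc(Br)cc5)CC4)cc3)nc2n1C1CCCC1` gives 90.3%. Going by the values given here, these two values lie within the usual scatter of each other, so compound 2 cannot be separated from compound 1, the only other compound measured so far. Compound 3 `CN(C)C(=O)c1cc2cnc(Nc3ccc(NC(=O)C4(C(=O)Nc5cccc(Br)c5)CC4)cc3)nc2n1C1CCCC1` differs from compound 2 in a single group: 3-bromophenyl in place of 4-bromophenyl on an amide-type nitrogen. The two structures have the same atoms, joined differently. Among the compounds with values here, one measured step bears on this change, because it alters the group on the same amide-type nitrogen: a number 1.7 percentage points higher from compound 1 to compound 2 (within the scatter). That swap of 2-fluorophenyl for 4-bromophenyl left the value within the scatter, so no clear shift is expected in this assay this time either. The expected result is a number 2.3 percentage points lower from compound 2 to compound 3 (within the scatter), which would not go beyond the scatter. Compound 3 is estimated at 88%, with an expected range from 78% to 95%.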

Compound 3, percent growth inhibition at one concentration: 92.2%
The estimate for compound 3 lay 4.2 percentage points below the measured number; low and high end bracket the measured number.
By their numbers in this assay, from the lowest: compounds 1, 2 and 3 (each within the scatter of the next).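

Swapping 4-bromophenyl for 3-bromophenyl on the amide-type nitrogen keeps the same atoms and alters only how they are joined, and in this assay it gives a number 1.9 percentage points higher from compound 2 to compound 3 (within the scatter), so this shift of the bromine alone cannot be told apart from repeat scatter. Against 2-fluorophenyl, the new group gives a number 3.6 percentage points higher from compound 1 to compound 3 (within the scatter), which means that none of the three substituted phenyl groups at this position can yet be separated from the others. No measurement here offers an explanation for this result.

Going by these compounds, it remains open whether this level of inhibition would hold with a phenyl ring carrying an amine or a carboxylic acid, or with a longer alkyl chain in place of the ring. Readings at a single concentration also leave open whether these three compounds would separate at lower concentrations.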